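From 4-fluorophenyl to 3,5-dimethylphenyl on a sulfur

The source may hold more compounds than are shown below. What is called first, only, known or untested is meant among the compounds shown, and "the series" means these compounds.

Measured in a functional assay on SMMC-7721 cells (Homo sapiens) for inhibition, read by CCK-8 assay, with a stated time of 72 h, tested at 2 uM; a higher number here means more inhibition of growth at the concentration tested, a lower number less inhibition of growth
- compound 1 `COc1ccc(SCc2ccc(C(=O)Nc3ccccc3N)cc2)cc1` gives 33.1%
- compound 2 `Cc1ccc(SCc2ccc(C(=O)Nc3ccccc3N)cc2)cc1` gives 25.1%
- compound 3 `Nc1ccccc1NC(=O)c1ccc(CSc2ccc(F)cc2)cc1` gives 6.58%

Compound 3 has the lowest value of the three, and its steps to both others lie beyond the scatter. Compound 4 `Cc1cc(C)cc(SCc2ccc(C(=O)Nc3ccccc3N)cc2)c1` differs from it by 3,5-dimethylphenyl in place of 4-fluorophenyl on a sulfur. Among the compounds with values here, two measured steps bear on this change: fluoro in place of methyl (a number 18.5 percentage points lower from compound 2 to compound 3 (beyond the scatter)) and fluoro in place of methoxy (a number 26.5 percentage points lower from compound 1 to compound 3 (beyond the scatter)). Both are modest, and both run downward on arriving at fluoro. Leaving fluoro should therefore reverse that direction, so a modest upward step is expected in this assay (a number 17.4 percentage points higher from compound 3 to compound 4 (beyond the scatter)). Within the data shown here, no measured compound carries two methyl groups, so the range stays wide. Compound 4 is estimated at 24% (expected range 10% to 40%).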

Compound 4, percent growth inhibition at one concentration: 29.1%
For compound 4 the middle estimate is 5.1 percentage points below the measured one, within the range that was stated.
By their numbers in this assay, from the lowest: compound 3; then compounds 2, 4 and 1 (each within the scatter of the next).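

In this assay, the change from 4-fluorophenyl to 3,5-dimethylphenyl on the sulfur gives a number 22.5 percentage points higher from compound 3 to compound 4 (beyond the scatter), but compound 4 cannot be told apart from the compounds with a single group on this ring: a number 4 percentage points higher from compound 2 to compound 4 (within the scatter), and a number 4 percentage points lower from compound 1 to compound 4 (within the scatter). Among these four compounds, the 4-fluorophenyl of compound 3 alone stands apart, and a second methyl group adds no step that can be read beyond the scatter. No measurement shown gives a reason for this.

Still open, from the compounds shown here alone, is how a ring carrying an amine or a carboxylic acid would read here. Also open, going by these compounds, is whether a longer chain on the sulfur in place of the ring would keep this level of growth inhibition.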